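The compounds below may be only part of what the source reports. "The series", "measured", "known", "first", "only" and "open" are said of these compounds alone.

Three sulfamate compounds sharing one core have been examined in an assay on HEK293 cells for inhibition of Steryl-sulfatase (Homo sapiens), tested at 0.1 uM; on this read-out higher numbers stand for a stronger effect at the one concentration tested and lower numbers for a weaker effect. Compound 1 `NS(=O)(=O)Oc1ccc2c(c1)CN(C(=O)c1cccc(N3CCN(c4ncccn4)CC3)c1)CC2` gives 1.6%, compound 2 `NS(=O)(=O)Oc1ccc2c(c1)CN(C(=O)c1ccc(N3CCN(Cc4ccccc4)CC3)cc1)CC2` gives 20.8%, and compound 3 `NS(=O)(=O)Oc1ccc2c(c1)CN(C(=O)c1cccc(N3CCN(Cc4ccccc4)CC3)c1)CC2` gives 0%. Compound 2 stands highest of the three; compound 1 sits beyond the scatter below it, and compound 3 sits further below, also beyond the scatter. The difference between the cores of compound 2 and compound 3 is not broken down here. Compound 1 differs from compound 3 by pyrimidin-2-yl in place of benzyl on an amine nitrogen in a ring, and that change produced a number 1.6 percentage points higher from compound 3 to compound 1 (within the scatter), a step within the scatter. Compound 4 `NS(=O)(=O)Oc1ccc2c(c1)CN(C(=O)c1ccc(N3CCN(c4ncccn4)CC3)cc1)CC2` has not yet been measured in this assay; it differs from compound 2 by pyrimidin-2-yl in place of benzyl on an amine nitrogen in a ring, the same change at the same place. Among the measured compounds shown here, for compound 4 the step is expected to be a number 1.8 percentage points lower from compound 2 to compound 4 (within the scatter), an expectation that rests on the single earlier step of a number 1.6 percentage points higher from compound 3 to compound 1 (within the scatter), which stayed within the scatter. In this assay compound 4 is therefore estimated at about 19%, most likely between 6% and 32%.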

Compound 4, a percentage reported as inhibition, at one concentration (the size of the read-out at that concentration, not a potency) in the Steryl-sulfatase assay: 14.7%
The estimate for compound 4 lay 4.3 percentage points above the measured number, within the range that was stated.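

In the Steryl-sulfatase assay compound 2 gives 20.8% and compound 4 gives 14.7%. In the Steryl-sulfatase assay, pyrimidin-2-yl in place of benzyl on an amine nitrogen in a ring gave a number 6.1 percentage points lower from compound 2 to compound 4 (within the scatter), and set beside the earlier step, the change reads alike on both cores: the same change on two cores in the Steryl-sulfatase assay, a number 1.6 percentage points higher (within the scatter) from compound 3 to compound 1 and a number 6.1 percentage points lower (within the scatter) from compound 2 to compound 4, 7.7 percentage points apart, within the scatter of two such steps

In a physicochemical assay for lipophilicity (on this read-out lower numbers stand for lower lipophilicity and higher numbers for higher lipophilicity), compound 2 gives 1.93 and compound 4 gives 1.93, and the same change gave no change at the digits printed from compound 2 to compound 4 (within the scatter), so on this core the two groups could be exchanged with no visible shift in either read-out. Among the compounds shown here, this does not show that the change is neutral in general: it rests on only two pairs at one concentration, which gives no potency, and in the Steryl-sulfatase assay compound 3 starts from 0%, where a fall could not appear.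

The compounds shown leave open how a methyl, an acetyl or a pyridin-2-yl group on that same amine nitrogen would read on these two cores. They also leave open whether the step stays this small once a carboxylic acid or a longer chain is added elsewhere on the shared core.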